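The source may hold more compounds than are shown below. What is called first, only, known or untested is meant among the compounds shown, and "the series" means these compounds.

Measured so far:
- compound 1, `CC(C)=CCC/C(C)=C/CC/C(C)=C/CC[C@]1(C)CCc2c(C)c(OC(=O)Nc3ccccc3)c(C)c(C)c2O1`, in a functional assay on MDA-MB-231 cells (Homo sapiens) for antiproliferative activity, read by MTT assay, with a stated time of 96 h; a higher number here means a weaker inhibitor, a lower number a stronger inhibitor: > 10000 nM
- compound 2, `CC(C)=CCC/C(C)=C/CC/C(C)=C/CC[C@]1(C)CCc2cc(OC(=O)NC(=O)Oc3ccccc3)cc(C)c2O1`, in this assay: "not determined" (no result reported)

Compound 1 reaches only a limit of the assay, so for it the number is not a measurement but a boundary; this is the line (the limit of > 10000 nM in this assay, at which 1 of the 2 values shown sits). Compound 2, which shares the long unsaturated side chain and the bicyclic core but carries a phenoxycarbonyl on the amide-type nitrogen, stands without any number in this assay, so there is no measured anchor for the step that follows.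

Compound 3, `CC(C)=CCC/C(C)=C/CC/C(C)=C/CC[C@]1(C)CCc2cc(OC(=O)NS(=O)(=O)c3ccc(C)cc3)cc(C)c2O1`, differs from compound 2 in one place: (4-methylphenyl)sulfonyl in place of phenoxycarbonyl on an amide-type nitrogen. Going by the values given here, with no measured step between these two compounds, no size or direction can be read from the data, and the only number in view is the limit of compound 1. For compound 3 the expectation in this assay is therefore wide: the estimate is 8000 nM, between 1500 nM and 40000 nM.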

Compound 3, half-maximal inhibitory concentration: 6600 nM
Compound 3: middle estimate off by 1.2-fold (0.08 log units), on the high side; the measured number falls inside the stated range.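

No new step can be read from the result for compound 3, as compound 2, which differs from it in one place, has no number to compare with in this assay. Going by these compounds, the effect of exchanging phenoxycarbonyl for (4-methylphenyl)sulfonyl stays open, and compound 1 offers only a limit: the limit of > 10000 nM in this assay, at which 1 of the 3 values shown sits.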